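This account rests on a few compounds, and the source may have more. Where it says the series, first, only, none or still open, it means among the compounds named here.

Working notes on the series.

Compound 1 `O=C(O)CCCCCCC(=O)Nc1ccc(C2=C(c3ccc(O)cc3)C3CC(S(=O)(=O)Oc4ccccc4C(F)(F)F)C2O3)cc1` carries an eight-carbon acid chain on the amide and a 2-(trifluoromethyl)phenoxy sulfonate on the shared core. In an ADME assay on Vero cells (Chlorocebus sabaeus) for inhibition, read by MTT assay, with a stated time of 72 h (a lower number here means a stronger inhibitor, a higher number a weaker inhibitor), compound 1 gives > 100000 nM, which is a limit of the assay and not a number. Compound 2 `O=C(O)CCCCCCC(=O)Nc1cccc(OS(=O)(=O)C2CC3OC2C(c2ccc(O)cc2)=C3c2ccc(O)cc2)c1` is measured in this assay at > 100000 nM, again a limit. Compound 3 `COc1ccccc1OS(=O)(=O)C1CC2OC1C(c1ccc(NC(=O)CCCCCCC(=O)NO)cc1)=C2c1ccc(O)cc1` shows in this assay a value of > 100000 nM, also a limit. Every value in hand therefore sits at the limit of > 100000 nM in this assay, at which 3 of the 3 values shown sit, so compound 1 stands with the rest of the series and nothing separates it from compound 2 or compound 3 on the numbers shown.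

Compound 4 `Cc1ccc(OS(=O)(=O)C2CC3OC2C(c2ccc(NC(=O)CCCCCCC(=O)O)cc2)=C3c2ccc(O)cc2)cc1` is the next member to be measured. It differs from compound 1 in one place: 4-methylphenyl in place of 2-(trifluoromethyl)phenyl on an oxygen, on an oxygen whose other neighbour is sulfonyl sulfur. Within the data shown here, no step between measured compounds is available to gauge a change of this kind, and the sulfonate aryl groups already present across compound 1, compound 2 and compound 3 all leave the values at the limit.

The step from compound 1 to compound 4 is therefore expected to be none beyond the scatter, estimated as a step that the limit leaves unreadable from compound 1 to compound 4. Compound 4 is expected to return a value of 150000 nM in this assay, with a range from 50000 nM to 500000 nM, most probably reported as a limit.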

Compound 4, half-maximal inhibitory concentration: > 100000 nM
Compound 4 ended at the assay's limit; the forecaster's own chance of this, stated with the estimate: 85%; the middle value is on the limit's open side.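

No step can be read from compound 1 to compound 4, as both stand at a limit of the assay: the limit of > 100000 nM in this assay, at which 4 of the 4 values shown sit.

What this assay would give for any of these compounds past the limit, and whether 4-methylphenyl and 2-(trifluoromethyl)phenyl differ there at all, stays open.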